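Replacing Pyrrolyl with Phenylsulfonyl on a Shared Core

The source may hold more compounds than are shown below. What is called first, only, known or untested is meant among the compounds shown, and "the series" means these compounds.

Compound 2 `COc1cc(OC)c2c(=O)cc(C(=O)Nc3ccc(-n4cccc4)cc3)[nH]c2c1` was examined in a functional assay on HepG2 cells (Homo sapiens) for antiproliferative activity, with a stated time of 72 h; on this read-out lower numbers stand for an effect already at smaller amounts and higher numbers for an effect only at larger amounts of compound. In this assay compound 2 gives only a limit, > 77000 nM. Its closest neighbour, compound 1 `COc1cc(OC)c2c(=O)cc(C(=O)Nc3ccc(Oc4cccnc4)cc3)[nH]c2c1`, also reaches only a limit in this assay, > 32100 nM. The step that the two limits leave unreadable from compound 1 to compound 2 therefore stays unreadable. Compound 3 `COc1cc(OC)c2c(=O)cc(C(=O)Nc3ccc(S(=O)(=O)c4ccccc4)cc3)[nH]c2c1` differs from compound 2 by phenylsulfonyl in place of 1H-pyrrol-1-yl on an aromatic carbon. Going by the values given here, no measured step bears on this change, and both measured compounds stop at their limits, so the expected step of an at least 1.5-fold lower number from compound 2 to compound 3 (0.18 log units; that floor lies within the scatter) is none that can be read. The value of compound 3 in this assay is estimated at 50000 nM, expected between 8000 nM and 150000 nM.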

Compound 3, half-maximal effective concentration: > 70600 nM
Compound 3 was reported as a limit; the forecaster's own chance of this, stated with the estimate: 80%; middle value at least 1.4-fold (0.14 log units) from the limit.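

In this assay compound 3 gives only a limit, > 70600 nM. Compound 1 and compound 2 also stop at limits, so no step among these three compounds can be read. The compounds shown leave open whether phenylsulfonyl, 1H-pyrrol-1-yl and (pyridin-3-yl)oxy differ at all in this assay.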